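The source may report more compounds than this note shows. Statements on the series, on what has been measured and on what is new or still open speak of the compounds shown alone.

Compound 1 `COc1ccc(-c2nc(/N=C(\N)NC3CCCCC3)sc2-c2ccc(OC)cc2)cc1` is one of the three measured compounds; in a functional assay with Oryctolagus cuniculus as the target (on this read-out higher numbers stand for weaker inhibition and lower numbers for stronger inhibition), compound 1 gives only a limit, > 1000 nM.
Compound 2 `COc1ccc(-c2nc(CN(C)C)sc2-c2ccc(OC)cc2)cc1`; in this assay compound 2 gives 96 nM.
Compound 3 `COc1ccc(-c2nc(CNC(=O)N3CCOCC3)sc2-c2ccc(OC)cc2)cc1`; in this assay compound 3 gives 660 nM.

Among the two numbers shown, compound 3 stands highest, and its nearest neighbour is compound 2, with a 6.9-fold higher number from compound 2 to compound 3 (0.84 log units; beyond the scatter). Compound 1 sits at the limit (the limit of > 1000 nM in this assay, at which 1 of the 3 values shown sits), so the step of an at least 1.5-fold lower number from compound 1 to compound 3 (0.18 log units; that floor lies within the scatter) rests on a floor that lies within the scatter, while an at least 10-fold lower number from compound 1 to compound 2 (1.01 log units; beyond the scatter) is large.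

Compound 4 `COc1ccc(-c2nc(CCC(=O)O)sc2-c2ccc(OC)cc2)cc1` has not been measured. It differs from compound 3 as follows: carboxymethyl in place of ((morpholin-4-yl)carbonyl)amino on a saturated chain carbon bound to an aromatic carbon

Among the compounds with values here, two measured steps bear on this change. The step from compound 2 to compound 3 exchanged dimethylamino for ((morpholin-4-yl)carbonyl)amino and raised the number modestly; the step from compound 1 to compound 2 exchanged a large ring-bearing group for a small chain group and lowered the number strongly. Compound 4 again carries a small chain group in place of a ring-bearing one, but carboxymethyl is not among the groups already measured, so the direction is uncertain. The step of a 1.3-fold lower number from compound 3 to compound 4 (0.12 log units; within the scatter) is therefore expected to stay close to or below the scatter. For compound 4 in this assay the estimate is 500 nM, within 150 nM to 2000 nM.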

Compound 4, half-maximal inhibitory concentration: < 100 nM
Compound 4: a limit, no number; the forecaster's own chance of this, stated with the estimate: 25%; at least 5.0-fold (0.69 log units) between middle value and limit.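

In this assay compound 4 gives < 100 nM, which is a limit of the assay and not a number. Even so, the exchange of ((morpholin-4-yl)carbonyl)amino for carboxymethyl on the saturated chain carbon bound to an aromatic carbon gives an at least 6.6-fold lower number from compound 3 to compound 4 (0.81 log units; beyond the scatter), and the comparison with the cyclohexyl-bearing group of the first compound gives an at least 10-fold lower number from compound 1 to compound 4 (1.00 log units; beyond the scatter). Until now dimethylamino was the only group on this carbon with a low number, whereas carboxymethyl holds carbon and oxygen only, so among the compounds shown a low number here does not depend on a nitrogen in the group, and both groups without a ring sit lower than the morpholine-bearing group of compound 3.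

Within the data shown here, the steps that end in a limit without a readable size, here the one linking compound 2 and compound 4, cannot be read, so the order of dimethylamino and carboxymethyl stays open. Also open, going by these compounds, is whether the methyl ester of the carboxylic acid, a primary amine or a longer chain ending in the carboxylic acid would keep the number low at this place.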